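The source may report more compounds than this note shows. Statements on the series, on what has been measured and on what is new or still open speak of the compounds shown alone.

Compound 1 `CCCC(C)C(=O)OCC(C)(C)CC1=C(O)C(=O)c2ccccc2C1=O`: 120 nM
Compound 2 `CCCCCC(=O)OCC(C)(C)CC1=C(O)C(=O)c2ccccc2C1=O`: 169000 nM

In an ADME assay on Vero cells (Chlorocebus sabaeus) for cytotoxicity, read by MTT assay (on this read-out higher numbers stand for weaker inhibition and lower numbers for stronger inhibition), compound 2 holds the higher of the two numbers, so it is the weaker inhibitor of the pair. Compound 3 `CCCCCCC(=O)OCC(C)(C)CC1=C(O)C(=O)c2ccccc2C1=O` makes one change to compound 2: methyl in place of hydrogen on a saturated chain carbon, five bonds along the chain from a carbonyl carbon. In words, this is methyl in place of hydrogen on a saturated chain carbon.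

Among the measured compounds shown here, only one measured step bears on this, and it is large: a 1400-fold higher number from compound 1 to compound 2 (3.15 log units; beyond the scatter). That step swaps 1-methylbutyl for pentyl and does not extend the chain, so it shows that this part of the molecule can matter but does not size the new change. Compound 3 lacks the 1-methylbutyl group of compound 1, so no change beyond the scatter is expected, with a small chance of a lower number. The expected step is a 1.4-fold lower number from compound 2 to compound 3 (0.15 log units; within the scatter). For compound 3 the estimated value is 120000 nM, with an expected range of 30000 nM to 300000 nM.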

Compound 3, half-maximal inhibitory concentration: 99300 nM
For compound 3 the middle estimate is 1.2-fold (0.08 log units) above the measured one, and the stated range covers the measured number.
By their numbers in this assay, from the lowest: compound 1; then compounds 3 and 2 (each within the scatter of the next).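

In this assay, a methyl in place of hydrogen on a saturated chain carbon, five bonds along the chain from a carbonyl carbon, gives a 1.7-fold lower number from compound 2 to compound 3 (0.23 log units; within the scatter), so lengthening the straight chain from pentyl to hexyl produces no change that can be told from the scatter. The large gap seen earlier is not tied to pentyl alone, as the hexyl chain shows it too, with an 830-fold higher number from compound 1 to compound 3 (2.92 log units; beyond the scatter). Nothing available explains either result.

Still open, going by these compounds, is whether the low number belongs to 1-methylbutyl specifically or would also appear with another branched group, such as 1-methylpropyl or 1-ethylpropyl. It is also unknown whether a longer straight chain, such as octyl, or a carboxylic acid at the chain end would stay in the same range.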